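Moving a hydroxyl around the ring on a pyridine scaffold

A few compounds are considered here, and "the series" means these few. Any claim that something is new, unique, unknown or untested is made for them only; others in the source may bear on it.

Of the compounds shown here, three have been measured in a functional assay on HCT-15 cells (Homo sapiens) for cytotoxicity, read by CCK-8 assay; a higher number here means a weaker inhibitor, a lower number a stronger inhibitor. Compound 1 `Oc1cccc(-c2cc(-c3ccsc3)cc(-c3cccc(O)c3)n2)c1` gives 1630 nM. Compound 2 `Oc1ccc(-c2cc(-c3ccsc3)cc(-c3cccc(O)c3)n2)cc1` gives 1180 nM in this assay. Compound 3 `Oc1cccc(-c2cc(-c3ccoc3)cc(-c3ccccc3O)n2)c1` reaches only the limit of this assay, > 50000 nM, so no number is known for it; at that limit sit (the limit of > 50000 nM in this assay, at which 1 of the 3 values shown sits).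

Compound 2 arises from compound 1 by one change, (4-hydroxyphenyl in place of 3-hydroxyphenyl on an aromatic carbon), and this produced a 1.4-fold lower number from compound 1 to compound 2 (0.14 log units; within the scatter). The same kind of change leads from compound 3 to compound 4 `Oc1ccc(-c2cc(-c3ccoc3)cc(-c3ccccc3O)n2)cc1`, namely (4-hydroxyphenyl in place of 3-hydroxyphenyl on an aromatic carbon). The surroundings differ: in compound 1 the changed position is meta to a 3-hydroxyphenyl group and meta to a thiophen-3-yl group, whereas in compound 3 it is meta to a 2-hydroxyphenyl group and meta to a furan-3-yl group. The difference between the two cores themselves is not broken down here.

For compound 4 in this assay the step from compound 3 is expected to be a number no higher from compound 3 to compound 4 (the limit leaves the size open), resting on the small effect seen in compound 2 with a 1.4-fold lower number from compound 1 to compound 2 (0.14 log units; within the scatter). Compound 4 is therefore estimated at 50000 nM, most likely again only a limit, between 15000 nM and 200000 nM.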

Compound 4, half-maximal inhibitory concentration: > 50000 nM
Compound 4 gave a limit, no number; the forecaster's own chance of this, stated with the estimate: 75%; the middle value sits exactly at the limit.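

Compound 3 and compound 4 both give only a limit in this assay and no number, so the step between them cannot be read: the limit of > 50000 nM in this assay, at which 2 of the 4 values shown sit.

The compounds shown leave open what numbers lie behind these two limits, and whether exchanging 3-hydroxyphenyl for 4-hydroxyphenyl on the core of compound 3 changes anything.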